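Amino to methylamino: compound 2 to compound 3

A few compounds are considered here, and "the series" means these few. Any claim that something is new, unique, unknown or untested is made for them only; others in the source may bear on it.

Going by the values given here, in an ADME assay on the whole organism (plasma, strain Balb) for pharmacokinetics, with Mus musculus as the target, read by LC-MS, at a dose of 10 mg/kg by the oral route (a higher number here means more compound in the circulation at the dose given, a lower number less compound in the circulation), compound 1 (`Cc1ccc(Cl)cc1-c1cc(-c2ncnc3[nH]ccc23)[nH]c1C(N)=O`) has "not determined" (no result reported) as its entry, and compound 2 (`CCc1ccc(Cl)cc1-n1cc(-c2cc(N)ncn2)cc1C(N)=O`) gives 7180 ng.h/mL as the only number available, so it cannot yet be ranked. Compound 3 (`CCc1ccc(Cl)cc1-n1cc(-c2cc(NC)ncn2)cc1C(N)=O`) differs from compound 2 in one place: methyl in place of hydrogen on a nitrogen on an aromatic ring. Among the compounds with values here, no measured pair shows this change. In this assay a small fall, within the usual scatter, is expected. The expected step is a 1.4-fold lower number from compound 2 to compound 3 (0.16 log units; within the scatter) and rests on the structural change alone. Compound 3 is estimated at 5000 ng.h/mL, with 1800 ng.h/mL to 12000 ng.h/mL as the expected range.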

Compound 3, area under the concentration-time curve: 1030 ng.h/mL
For compound 3 the middle estimate is 4.9-fold (0.69 log units) above the measured one, and the stated range ends above it.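

In this assay, going by these compounds alone, amino to methylamino gives a 7.0-fold lower number from compound 2 to compound 3 (0.84 log units; beyond the scatter), the first step with a size attached. A single methyl on this nitrogen is therefore enough to move the read-out beyond the scatter, so this position does not tolerate every small change. Nothing at hand explains the fall.

On these data alone, whether the fall belongs to methyl alone or to any group on this nitrogen stays open; an ethyl, an acetyl or a dimethylamino group would bear on that. As far as these compounds go, whether methyl has a similar effect on the core of compound 1 also stays open.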